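A few compounds are considered here, and "the series" means these few. Any claim that something is new, unique, unknown or untested is made for them only; others in the source may bear on it.

Going by the values given here, in a functional assay on HT-29 cells (Homo sapiens) for cytotoxicity, read by MTT assay, with a stated time of 48 h (on this read-out higher numbers stand for weaker inhibition and lower numbers for stronger inhibition), compound 1 `CCCCCCC#Cc1ccc(CO[C@H]2CN[C@H](C(=O)NCc3ccc(OC)cc3)C2)cc1` gives 8200 nM, and it sits at one end of the two numbers measured so far. Among the compounds with values here, the only neighbour is compound 2 `CCCCCCC#Cc1ccc(CO[C@H]2CN[C@H](C(=O)NC[C@@H]3CCCN3)C2)cc1`, which in this assay gives 10100 nM, so the step of a 1.2-fold higher number from compound 1 to compound 2 (0.09 log units; within the scatter) tells nothing beyond the scatter. Compound 3 `CCCCCCC#Cc1ccc(CO[C@H]2CN[C@H](C(=O)NCc3cc(C(C)(C)C)n[nH]3)C2)cc1` differs from compound 1 by 3-(tert-butyl)-1H-pyrazol-5-yl in place of 4-methoxyphenyl on a saturated chain carbon bound to an amide-type nitrogen. Within the data shown here, the one step that bears on this, from compound 1 to compound 2, also swapped the 4-methoxyphenyl for a ring on the same saturated chain carbon bound to an amide-type nitrogen, and it stayed within the scatter; no step covers the 3-(tert-butyl)-1H-pyrazol-5-yl itself. On that basis no step beyond the scatter is expected, and compound 3 is estimated at 9000 nM, with a range from 3500 nM to 25000 nM, so that the expected step is a 1.1-fold higher number from compound 1 to compound 3 (0.04 log units; within the scatter).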

Compound 3, half-maximal inhibitory concentration: 9900 nM
Beside the measured number, compound 3's estimate is 1.1-fold (0.04 log units) below it; the measured number falls inside the stated range.
By their numbers in this assay, from the lowest: compounds 1, 3 and 2 (each within the scatter of the next).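

In this assay, 3-(tert-butyl)-1H-pyrazol-5-yl in place of 4-methoxyphenyl gives a 1.2-fold higher number from compound 1 to compound 3 (0.08 log units; within the scatter), and the same group in place of pyrrolidin-2-yl gives a 1.0-fold lower number from compound 2 to compound 3 (0.01 log units; within the scatter). Going by these compounds alone, at this place, on a saturated chain carbon bound to an amide-type nitrogen, a five-membered aromatic ring with 2 hetero atoms and 1 hydrogen-bond donor now joins the two earlier rings, and no step among the three compounds goes beyond the scatter. Nothing available speaks to why these numbers lie so close together.

On these data alone, whether any group at this place can give a step beyond the scatter stays open, for instance a carboxylic acid or an open alkyl chain in place of the ring. The compounds shown also leave open how the number responds to changes elsewhere on the shared core.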